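Moving two fluorines around the methoxyphenyl group

The source may hold more compounds than are shown below. What is called first, only, known or untested is meant among the compounds shown, and "the series" means these compounds.

Compound 1, `COc1ccccc1C1CCN(c2ccn3c(CC4CC4)nnc3c2Cl)CC1`, gives 20 nM in a functional assay on CHO cells for agonist activity at metabotropic glutamate receptor 2 (Homo sapiens), read by scintillation counting and GTPgammaS binding, with a stated time of 30 min; on this read-out higher numbers stand for an effect only at larger amounts of compound and lower numbers for an effect already at smaller amounts.
Compound 2, `COc1c(F)cccc1C1CCN(c2ccn3c(CC4CC4)nnc3c2Cl)CC1`, gives 37 nM in this assay.
Compound 3, `COc1c(F)ccc(F)c1C1CCN(c2ccn3c(CC4CC4)nnc3c2Cl)CC1`, gives 7.5 nM in this assay.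

Among these three, compound 3 gives the lowest number: the step of a 2.7-fold lower number from compound 1 to compound 3 (0.43 log units; beyond the scatter) and the step of a 4.9-fold lower number from compound 2 to compound 3 (0.69 log units; beyond the scatter) both lie beyond the scatter. Compound 4, `COc1ccc(F)c(F)c1C1CCN(c2ccn3c(CC4CC4)nnc3c2Cl)CC1`, has the same atoms as compound 3 in a different arrangement: 2,3-difluoro-6-methoxyphenyl in place of 3,6-difluoro-2-methoxyphenyl on a saturated ring carbon. Among the measured compounds shown here, no measured step shows exactly this kind of rearrangement. For the measured compounds named here, the steps that bear on it concern adding fluorine: a 1.9-fold higher number from compound 1 to compound 2 (0.27 log units; within the scatter) stays within the scatter, while a 4.9-fold lower number from compound 2 to compound 3 (0.69 log units; beyond the scatter) goes beyond it. Placing fluorine thus changed the numbers in both directions, so where the two fluorines sit matters, but the direction for compound 4 cannot be read off from the three compounds. The estimate for compound 4 therefore sits between the extremes seen so far, with a wide range: an expected 15 nM, between 5 nM and 50 nM, which would mean an expected step of a 2.0-fold higher number from compound 3 to compound 4 (0.30 log units; within the scatter) in this assay.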

Compound 4, half-maximal effective concentration: 9.3 nM
Beside the measured number, compound 4's estimate is 1.6-fold (0.21 log units) above it; the range from low to high includes it.
By their numbers in this assay, from the lowest: compounds 3 and 4 (each within the scatter of the next); then compounds 1 and 2 (each within the scatter of the next).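

Rearranging the ring from 3,6-difluoro-2-methoxyphenyl to 2,3-difluoro-6-methoxyphenyl, with the same atoms on the same saturated ring carbon, leaves the result in this assay within the scatter: a 1.2-fold higher number from compound 3 to compound 4 (0.09 log units; within the scatter). The earlier compounds offered only one difluoro arrangement, whereas this second one also lies beyond the scatter of the compounds with less fluorine, with a 4.0-fold lower number from compound 2 to compound 4 (0.60 log units; beyond the scatter) and a 2.2-fold lower number from compound 1 to compound 4 (0.33 log units; beyond the scatter), so among these four compounds the low numbers are not tied to a single placement of the two fluorines. Nothing reported here gives a measured reason for these steps.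

From the compounds shown here alone, it remains open whether a chlorine or a trifluoromethyl group could take the place of either fluorine with a similar result. An ethoxy or hydroxyl group in place of the methoxy group is equally unexplored in the compounds shown.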